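Cytotoxicity notes on a pyrazolopyridine amide series, compound 1 to 3

The compounds below may be only part of what the source reports. "The series", "measured", "known", "first", "only" and "open" are said of these compounds alone.

Measured so far:
- compound 1, `Nc1nn(CC(=O)NCCO)c2nc(-c3ccccc3)cc(C(F)(F)F)c12`: 69500 nM
- compound 2, `Nc1nn(CC(=O)NC2CC2)c2nc(-c3ccccc3)cc(C(F)(F)F)c12`: "not active" (no number reported)

Among the compounds with values here, compound 1 is the only compound of the pair with a numerical read-out in a functional assay on HeLa cells (Homo sapiens) for cytotoxicity, read by MTT assay, with a stated time of 24 h; a higher number here means a weaker inhibitor, a lower number a stronger inhibitor; in this assay compound 1 gives 69500 nM, a weak result. Within the data shown here, compound 2 carries a cyclopropyl amide in place of the 2-hydroxyethyl amide, and in this assay compound 2 is reported as "not active" (no number reported) without a number, so no step between measured compounds can be stated.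

Compound 3, `Nc1nn(CC(=O)NCC(=O)O)c2nc(-c3ccccc3)cc(C(F)(F)F)c12`, differs from compound 1 by carboxy in place of hydroxymethyl on a saturated chain carbon bound to an amide-type nitrogen. Among the measured compounds shown here, no measured step covers this change. Given the weak value of compound 1 at 69500 nM, the expected step in this assay from compound 1 to compound 3 is a 1.2-fold higher number from compound 1 to compound 3 (0.06 log units; within the scatter), that is, no movement beyond the usual scatter. Compound 3 is estimated at 80000 nM, with a range from 25000 nM to 250000 nM.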

Compound 3, half-maximal inhibitory concentration: 19100 nM
Beside the measured number, compound 3's estimate is 4.2-fold (0.62 log units) above it; measured number below the stated range.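

On a saturated chain carbon bound to an amide-type nitrogen, carboxy in place of hydroxymethyl gives a 3.6-fold lower number from compound 1 to compound 3 (0.56 log units; beyond the scatter) in this assay and so moves the read-out beyond the usual scatter. Within the data shown here, this is the first numerical step, and it shows that the read-out responds to a change at the end of the amide side chain, with the shared core left unchanged. The step is modest, and no measurement shown here accounts for it.

Compound 2 remains without a number, so its cyclopropyl amide cannot be placed on the same scale as compound 1 and compound 3. Still open, from the compounds shown here alone, is whether a 2-aminoethyl amide, the methyl ester of the carboxymethyl amide or a longer chain such as 3-carboxypropyl would shift the number in the same direction.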